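Pyrrolidine and piperidine caps on the imidazole nitrogen

The source may report more compounds than this note shows. Statements on the series, on what has been measured and on what is new or still open speak of the compounds shown alone.

Measured compounds:
compound 1 `CN1CCN(c2ccc(Nc3ncc4nc(Nc5ccc(F)cc5)n([C@H]5CCNC5)c4n3)cc2)CC1`: 1220 nM
compound 2 `CN1CCN(c2ccc(Nc3ncc4nc(Nc5ccc(F)cc5)n([C@@H]5CCN(S(=O)(=O)C6CC6)C5)c4n3)cc2)CC1`: 2.5 nM
compound 3 `CN1CCN(c2ccc(Nc3ncc4nc(Nc5ccc(F)cc5)n([C@H]5CCCN(C(=O)CO)C5)c4n3)cc2)CC1`: 1.8 nM

Compound 3 holds the lowest number of the three in a functional assay on HCC827 cells (Homo sapiens) for antiproliferative activity, read by MTT assay, with a stated time of 72 h; a lower number here means a stronger inhibitor, a higher number a weaker inhibitor; against compound 2 this is a 1.4-fold lower number from compound 2 to compound 3 (0.14 log units; within the scatter), and against compound 1 it is a 680-fold lower number from compound 1 to compound 3 (2.83 log units; beyond the scatter). Both capped rings sit far below the uncapped pyrrolidin-3-yl of compound 1: a 490-fold lower number from compound 1 to compound 2 (2.69 log units; beyond the scatter) and a 680-fold lower number from compound 1 to compound 3 (2.83 log units; beyond the scatter).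

Compound 4 `CN1CCN(c2ccc(Nc3ncc4nc(Nc5ccc(F)cc5)n([C@H]5CCN(S(=O)(=O)C6CC6)C5)c4n3)cc2)CC1` differs from compound 3 by 1-(cyclopropylsulfonyl)pyrrolidin-3-yl in place of 1-((hydroxymethyl)carbonyl)piperidin-3-yl on an aromatic nitrogen. Among the compounds with values here, the only step that bears on it directly is the one from compound 2 to compound 3, which compares the two capped rings and lies within the scatter. Within the data shown here, compound 4 carries the same cap as compound 2 but with the other configuration at the defined stereocentre, and no measured pair tells what that change does here. The expected step is therefore a 4.4-fold higher number from compound 3 to compound 4 (0.65 log units; beyond the scatter), with a wide range to allow for the untested configuration. Compound 4 is estimated at 8 nM, between 2 nM and 80 nM.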

Compound 4, half-maximal inhibitory concentration: 7.5 nM
Beside the measured number, compound 4's estimate is 1.1-fold (0.03 log units) above it; measured number inside the range.
By their numbers in this assay, from the lowest: compounds 3 and 2 (each within the scatter of the next); then compound 4; then compound 1.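

With the 1-(cyclopropylsulfonyl)pyrrolidin-3-yl group on the aromatic nitrogen, this assay responds to configuration alone, with a 3.0-fold higher number from compound 2 to compound 4 (0.48 log units; beyond the scatter). The cap outweighs that change, with a 160-fold lower number from compound 1 to compound 4 (2.21 log units; beyond the scatter), so the S form still stays far below the uncapped pyrrolidin-3-yl. Against the 1-((hydroxymethyl)carbonyl)piperidin-3-yl group there is a 4.2-fold higher number from compound 3 to compound 4 (0.62 log units; beyond the scatter), while compound 2 lies within the scatter of compound 3, so the comparison between these two caps depends on which configuration of the sulfonyl cap is taken: the fact that compounds 2 and 4 differ only in the configuration as drawn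

Whether configuration counts to the same degree for the 1-((hydroxymethyl)carbonyl)piperidin-3-yl group remains open, as the compounds shown carry that cap in one form only. Also open, from the compounds shown here alone, is whether a methylsulfonyl or acetyl cap on the same ring nitrogen would hold numbers this low.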